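Moving from ortho-fluorine to para-methyl on the benzamide

This account rests on a few compounds, and the source may have more. Where it says the series, first, only, none or still open, it means among the compounds named here.

Going by the values given here, compound 2 `O=C1Nc2ccc(Cl)cc2C(CNC(=O)c2ccccc2F)(C(F)(F)F)O1` is the weaker of the two compounds measured so far: in an assay for inhibition of very long chain fatty acid elongase 6 (Homo sapiens) (a lower number here means a stronger inhibitor, a higher number a weaker inhibitor), compound 2 gives 539 nM. Among the compounds with values here, compound 1 `O=C1Nc2ccc(Cl)cc2C(CNC(=O)c2cccc(F)c2)(C(F)(F)F)O1` gives 261 nM in this assay, and the single measured step, a 2.1-fold higher number from compound 1 to compound 2 (0.31 log units; beyond the scatter), shows that relocating the fluorine on the benzamide ring already shifts the number by a modest but real margin. Compound 3 `Cc1ccc(C(=O)NCC2(C(F)(F)F)OC(=O)Nc3ccc(Cl)cc32)cc1` carries a different change at the same carbonyl carbon: 4-methylphenyl in place of 2-fluorophenyl on a carbonyl carbon. Within the data shown here, only the step of a 2.1-fold higher number from compound 1 to compound 2 (0.31 log units; beyond the scatter) bears on this position, and it concerns fluorine placement, not replacement of fluorine by a methyl group, so no measured step addresses the present change directly. A step of roughly the same modest size is expected, with direction uncertain. Compound 3 is therefore estimated at 400 nM, within a range of 130 nM to 1200 nM, which corresponds to an expected step of a 1.3-fold lower number from compound 2 to compound 3 (0.13 log units; within the scatter).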

Compound 3, half-maximal inhibitory concentration: 38 nM
Beside the measured number, compound 3's estimate is 11-fold (1.02 log units) above it; measured number outside the range, below it.
By their numbers in this assay, from the lowest: compound 3; then compound 1; then compound 2.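

Until now this position had shown only a modest response to moving a fluorine around the ring, but exchanging the fluorophenyl group for 4-methylphenyl on the same carbonyl carbon gives a 14-fold lower number from compound 2 to compound 3 (1.15 log units; beyond the scatter) and a 6.9-fold lower number from compound 1 to compound 3 (0.84 log units; beyond the scatter). Both steps lie beyond the scatter, so compound 3 is the strongest of the three compounds in this assay, and the aryl group on this carbonyl carbon emerges as a strong determinant of the number. The evidence at hand offers no explanation for this gain.

The change swaps the substituent and alters its place on the ring at once, so these compounds cannot show which of the two matters. Groups such as 4-fluorophenyl, 3-methylphenyl and 4-ethylphenyl on the same carbonyl carbon would separate these contributions and show how far the gain extends.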